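Methoxy in place of iodo on the shared core

A few compounds are considered here, and "the series" means these few. Any claim that something is new, unique, unknown or untested is made for them only; others in the source may bear on it.

In a functional assay on MOLT-4 cells (Homo sapiens) for antiproliferative activity, with a stated time of 48 h (on this read-out higher numbers stand for weaker inhibition and lower numbers for stronger inhibition), compound 1 (`Nc1ccc(/C=C/C(=O)c2ccccc2)cc1`) gives 10000 nM while compound 2 (`Nc1ccc(/C=C/C(=O)c2ccc(F)cc2)cc1`) gives 12000 nM and compound 3 (`Nc1ccc(/C=C/C(=O)c2ccc(I)cc2)cc1`) gives 7500 nM on the same read-out. Compound 3 therefore stands level with the other two, as all three values lie within the scatter of one another.

Compound 4 (`COc1ccc(C(=O)/C=C/c2ccc(N)cc2)cc1`) differs from compound 3 by one change: methoxy in place of iodo on an aromatic carbon (methoxy in place of iodo on an aromatic carbon, para to a large group).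

Among the measured compounds shown here, the steps that bear on it are the swaps at that same carbon: a 1.2-fold higher number from compound 1 to compound 2 (0.08 log units; within the scatter) for fluoro in place of hydrogen, a 1.3-fold lower number from compound 1 to compound 3 (0.12 log units; within the scatter) for iodo in place of hydrogen and a 1.6-fold lower number from compound 2 to compound 3 (0.20 log units; within the scatter) for iodo in place of fluoro. Each of them stays within the scatter. For the measured compounds named here, no methoxy compound has a measured value yet, so the expectation rests on these small steps alone, and no step beyond the scatter is expected in either direction. The estimated step is a 1.2-fold higher number from compound 3 to compound 4 (0.08 log units; within the scatter) and is expected to stay within the scatter. In this assay the estimate for compound 4 is 9000 nM with a range from 4000 nM to 20000 nM expected.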

Compound 4, half-maximal inhibitory concentration: 19000 nM
Estimate against measurement, compound 4: 2.1-fold (0.32 log units) below, and the stated range covers the measured number.
By their numbers in this assay, from the lowest: compounds 3, 1, 2 and 4 (each within the scatter of the next, the first and the last beyond it).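

In this assay, among the compounds shown here, methoxy on this aromatic carbon gives the first step at the position that lies beyond the scatter (a 2.5-fold higher number from compound 3 to compound 4 (0.40 log units; beyond the scatter)), and the step is modest. Against the other two compounds, methoxy stays within the scatter (a 1.6-fold higher number from compound 2 to compound 4 (0.20 log units; within the scatter) and a 1.9-fold higher number from compound 1 to compound 4 (0.28 log units; within the scatter)), so the series separates iodo from methoxy but does not separate methoxy from fluoro or hydrogen. No measurement at hand accounts for the difference between iodo and methoxy.

The compounds shown leave open where a hydroxy, ethoxy or chloro group on this carbon would fall relative to iodo and methoxy. They also leave open whether the iodo-to-methoxy step persists when a dimethylamino group stands in place of the amino group on the shared core.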